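The source may report more compounds than this note shows. Statements on the series, on what has been measured and on what is new or still open speak of the compounds shown alone.

In a functional assay on MGC-803 cells (Homo sapiens) for antiproliferative activity, read by MTT assay, with a stated time of 72 h (a lower number here means a stronger inhibitor, a higher number a weaker inhibitor), the measured compounds are these
- compound 1 `Oc1c(Br)cc(Br)cc1/C=N/NC(=S)N1CCOCC1` gives 20400 nM
- compound 2 `C/C(=N\NC(=S)N1CCOCC1)c1ccccc1` gives 32600 nM

Compound 2, at 32600 nM, sits within the usual scatter of compound 1, so neither of the two can be called the stronger inhibitor. The next compound to be tested is compound 3 `C/C(=N\NC(=S)N1CCOCC1)c1ccccc1O`. It is compound 2 with one change, (hydroxy in place of hydrogen on an aromatic carbon), which puts hydroxy in place of hydrogen on an aromatic carbon, ortho to a large group. Among the measured compounds shown here, no measured pair shows this change on its own, so the data give no direct guide to its size in this assay. A modest shift toward a lower number seems the likeliest outcome, though it may not clear the scatter. The estimated change is a 2.2-fold lower number from compound 2 to compound 3 (0.34 log units; beyond the scatter). For compound 3 the expected value is 15000 nM, with an estimated range from 4000 nM to 40000 nM.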

Compound 3, half-maximal inhibitory concentration: 11200 nM
Compound 3: middle estimate off by 1.3-fold (0.13 log units), on the high side; measured number inside the range.
By their numbers in this assay, from the lowest: compounds 3, 1 and 2 (each within the scatter of the next, the first and the last beyond it).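

In this assay, among the compounds shown here, hydroxy in place of hydrogen on an aromatic carbon, ortho to a large group, gives a 2.9-fold lower number from compound 2 to compound 3 (0.46 log units; beyond the scatter) as the first step between two compounds that differ in one place. The earlier compounds shown here could not show this: it means that this single change at this position can move the number beyond the usual scatter, although the step is only modest. No independent measurement explains the shift.

Going by these compounds, it remains open whether another group at this same position, such as an amine, a methoxy group or a carboxylic acid, would give a larger step, a smaller one or none. On these data alone, it is also open whether hydroxy would give a similar step elsewhere on the ring.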